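A few compounds are considered here, and "the series" means these few. Any claim that something is new, unique, unknown or untested is made for them only; others in the source may bear on it.

Two compounds of the series have numbers in a functional assay on MKN-45 cells (Homo sapiens) for inhibition, with a stated time of 72 h; a lower number here means a stronger inhibitor, a higher number a weaker inhibitor. Compound 1 `COc1ccc(S(=O)(=O)N2CCc3cccc(-c4ccc(F)c(F)c4)c32)cc1` gives 55.5 nM, the lowest of the two; compound 2 `COc1ccc(S(=O)(=O)n2ccc3cccc(-c4ccc(C#N)cc4)c32)cc1` gives 143 nM, a gap that lies beyond the scatter. Compound 3 `COc1ccc(S(=O)(=O)N2CCc3cccc(-c4cccnc4)c32)cc1` awaits measurement in this assay; it differs from compound 1 by pyridin-3-yl in place of 3,4-difluorophenyl on an aromatic carbon. Among the measured compounds shown here, no measured pair shows this change on its own, so the expectation rests on the change itself. Compound 3 is expected to be the weaker inhibitor, by a step of a 2.7-fold higher number from compound 1 to compound 3 (0.43 log units; beyond the scatter). The estimate for compound 3 is 150 nM, within 50 nM to 500 nM.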

Compound 3, half-maximal inhibitory concentration: 68.5 nM
Estimate against measurement, compound 3: 2.2-fold (0.34 log units) above, and the stated range covers the measured number.
By their numbers in this assay, from the lowest: compounds 1 and 3 (each within the scatter of the next); then compound 2.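

On an aromatic carbon of the shared core, pyridin-3-yl in place of 3,4-difluorophenyl gives a 1.2-fold higher number from compound 1 to compound 3 (0.09 log units; within the scatter) in this assay and thus no step beyond the scatter. This position therefore holds its number with a ring carrying a hetero atom and no fluorine, a reading that rests on this single pair. No measured evidence gives a reason for this result.

Going by these compounds, whether an amine or a carboxylic acid on this carbon would hold the number in this assay stays open. Compound 2 differs from compound 1 in more than one place and cannot be read for this position.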